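Trichlorophenyl sulfonamide joins three analogues sitting at the limit

This account rests on a few compounds, and the source may have more. Where it says the series, first, only, none or still open, it means among the compounds named here.

Compound 1 `O=S(=O)(NC1=NCCN1C(=S)SN1CCn2c1nsc2=S)c1ccccc1` is the starting point of this account. In a functional assay on KYSE-510 cells (Homo sapiens) for antiproliferative activity, read by crystal violet staining, with a stated time of 96 h (a lower number here means a stronger inhibitor of growth, a higher number a weaker inhibitor of growth), compound 1 gives >= 20000 nM, which is a limit of the assay rather than a number. Two compounds built on the same core were measured beside it. Compound 2 `Cc1cc(C)c(S(=O)(=O)NC2=NCCN2C(=S)SN2CCn3c2nsc3=S)c(C)c1` carries a 2,4,6-trimethylphenyl group on the sulfonyl sulfur, and in this assay compound 2 gives >= 20000 nM, again a limit. Compound 3 `O=[N+]([O-])c1ccc(S(=O)(=O)NC2=NCCN2C(=S)SN2CCn3c2nsc3=S)cc1` carries a nitro group on an aromatic carbon, and in this assay compound 3 gives >= 20000 nM, also a limit. All three values share one feature: the limit of >= 20000 nM in this assay, at which 3 of the 3 values shown sit. The steps a step that the two limits leave unreadable from compound 1 to compound 2, a step that the two limits leave unreadable from compound 1 to compound 3 and a step that the two limits leave unreadable from compound 2 to compound 3 therefore cannot be read in size or direction.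

Compound 4 `O=S(=O)(NC1=NCCN1C(=S)SN1CCn2c1nsc2=S)c1ccc(Cl)c(Cl)c1Cl` differs from compound 1 in one place: 2,3,4-trichlorophenyl in place of phenyl on a sulfonyl sulfur. Within the data shown here, the three measured steps all alter the group on the sulfonyl sulfur, and none of them yields a readable size, so the only guide is that every measured value sits at the limit. One therefore expects a step of a number no higher from compound 1 to compound 4 (the limit leaves the size open), nothing beyond the scatter. Compound 4 is expected to give an estimated 20000 nM in this assay, with a range from 8000 nM to 50000 nM, most probably reported again only as a limit.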

Compound 4, concentration for 50% growth inhibition: >= 20000 nM
Compound 4: only a limit was reported; the forecaster's own chance of this, stated with the estimate: 80%; the middle value sits exactly at the limit.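

No step from compound 1, compound 2 or compound 3 to compound 4 can be read in size or direction, as each value is only a limit: the limit of >= 20000 nM in this assay, at which 4 of the 4 values shown sit.

The compounds shown leave open how strongly, if at all, each one inhibits growth, and whether the group on the sulfonyl sulfur makes any difference.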